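Hydroxyalkyl side chain: from compound 2 to compound 3

The source may hold more compounds than are shown below. What is called first, only, known or untested is meant among the compounds shown, and "the series" means these compounds.

- compound 1 `COc1cc2c(c(OC)c1OC)-c1cc3cc(CO)oc3cc1C(O)CC2`: 16 nM
- compound 2 `COc1cc2c(c(OC)c1OC)-c1cc3cc(C(C)O)oc3cc1C(O)CC2`: 30 nM

In a functional assay on BXPC-3 cells (Homo sapiens) for cytotoxicity, read by MTT assay, with a stated time of 72 h (a lower number here means a stronger inhibitor, a higher number a weaker inhibitor), compound 2 gives 30 nM, which cannot be separated from compound 1 within the scatter. Compound 3 `COc1cc2c(c(OC)c1OC)-c1cc3cc(CCO)oc3cc1C(O)CC2` has 2-hydroxyethyl in place of 1-hydroxyethyl on an aromatic carbon. Within the data shown here, one measured step bears on this side chain: a 1.9-fold higher number from compound 1 to compound 2 (0.27 log units; within the scatter). As that step stayed within the scatter, no change beyond the scatter is expected in this assay, though a single step is thin support. The estimated change is a 1.3-fold lower number from compound 2 to compound 3 (0.10 log units; within the scatter). The expected value for compound 3 is 24 nM, with an estimated range of 10 nM to 60 nM.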

Compound 3, half-maximal inhibitory concentration: 400 nM
Compound 3: the middle estimate sits 17-fold (1.22 log units) below what was measured; the whole stated range lies below it.
By their numbers in this assay, from the lowest: compounds 1 and 2 (each within the scatter of the next); then compound 3.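

In this assay, the side chain on the aromatic carbon next to the ring oxygen proves sensitive to how its atoms are joined: 2-hydroxyethyl in place of 1-hydroxyethyl, with the same atoms, gives a 13-fold higher number from compound 2 to compound 3 (1.12 log units; beyond the scatter). Set against hydroxymethyl, the same group gives a 25-fold higher number from compound 1 to compound 3 (1.40 log units; beyond the scatter), whereas the methyl added in compound 2 stayed within the scatter, so across these three compounds the number follows where the hydroxy sits on the chain, not the chain's size alone. Nothing at hand accounts for this loss.

Still open, going by these compounds, is whether an amine or a carboxylic acid on this carbon would track compound 3 or the pair of compound 1 and compound 2. A longer chain ending in hydroxy is equally unresolved.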